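From Vinyl to Ethynyl on a Silent Series

The compounds below may be only part of what the source reports. "The series", "measured", "known", "first", "only" and "open" are said of these compounds alone.

Measured in a functional assay on HCT-116 cells (Homo sapiens) for cytotoxicity, with a stated time of 3 days; a higher number here means a weaker inhibitor, a lower number a stronger inhibitor:
- compound 1 `C=Cc1nc2ccccc2s1`: > 40000 nM (a limit)
- compound 2 `CC#Cc1nc(C(=O)OCC)cs1`: > 40000 nM (a limit)
- compound 3 `C=Cc1nc(C(=O)OCC)cs1`: > 40000 nM (a limit)

Compound 3 has no exact number, and its > 40000 nM is a limit. It shares this with the other two compounds, as the record shows: the limit of > 40000 nM in this assay, at which 3 of the 3 values shown sit.

Compound 4 `C#Cc1nc(C(=O)OCC)cs1` carries ethynyl in place of vinyl on an aromatic carbon.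

Going by the values given here, the one measured step that bears on this change is a step that the two limits leave unreadable from compound 2 to compound 3. It gives no size to build on, so no readable step is expected in this assay, in either direction. The estimated step is a number no higher from compound 3 to compound 4 (the limit leaves the size open). For compound 4 the expected value is 40000 nM, with an estimated range from 12000 nM to 80000 nM.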

Compound 4, half-maximal inhibitory concentration: > 40000 nM
Compound 4 was reported as a limit; the forecaster's own chance of this, stated with the estimate: 70%; the middle value sits exactly at the limit.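

No step among compound 2, compound 3 and compound 4 can be read, as all three sit at the same limit: the limit of > 40000 nM in this assay, at which 4 of the 4 values shown sit.

The compounds shown leave open whether vinyl, ethynyl or prop-1-yn-1-yl makes any difference in this assay.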